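A few compounds are considered here, and "the series" means these few. Any claim that something is new, unique, unknown or untested is made for them only; others in the source may bear on it.

Measured compounds in a functional assay on A549 cells (Homo sapiens) for antiproliferative activity, read by MTT assay; a lower number here means a stronger inhibitor, a higher number a weaker inhibitor:
- compound 1 `O=C1N=C(N2CCC[C@H]2C(=O)Nc2ccc3ncnc(Nc4cccc(Cl)c4)c3c2)S/C1=C/c1cccs1`: compound 1 gives 6100 nM
- compound 2 `O=C1N=C(N2CCC[C@H]2C(=O)Nc2ccc3ncnc(Nc4cccc(Cl)c4)c3c2)S/C1=C/c1ccccc1[N+](=O)[O-]`: compound 2 gives > 50000 nM, a limit of the assay
- compound 3 `O=C1N=C(N2CCC[C@H]2C(=O)Nc2ccc3ncnc(Nc4cccc(Cl)c4)c3c2)S/C1=C/c1ccc2ccccc2n1`: compound 3 gives > 50000 nM, a limit of the assay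

Compound 2 stands at the limit, so its value is not a number; it sits at the limit of > 50000 nM in this assay, at which 2 of the 3 values shown sit, together with compound 3, and only compound 1 yields a read number.

The step to compound 4 `Cc1cccc(/C=C2/SC(N3CCC[C@H]3C(=O)Nc3ccc4ncnc(Nc5cccc(Cl)c5)c4c3)=NC2=O)n1` is 6-methylpyridin-2-yl in place of 2-nitrophenyl on a double-bonded chain carbon bound to a double-bonded ring carbon.

Among the compounds with values here, no measured step changes 2-nitrophenyl into 6-methylpyridin-2-yl. Within the data shown here, the steps that bear on this position are an at least 8.1-fold higher number from compound 1 to compound 2 (0.91 log units; beyond the scatter) and an at least 8.1-fold higher number from compound 1 to compound 3 (0.91 log units; beyond the scatter), both moving away from thiophen-2-yl toward the limit. The step that the two limits leave unreadable from compound 2 to compound 3 shows that two groups on this carbon can both sit at the limit, so a change there need not move the number at all.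

Given that compound 2 starts at the limit, compound 4 is expected to come out with a step of an at least 1.4-fold lower number from compound 2 to compound 4 (0.15 log units; that floor lies within the scatter) that is not readable with confidence, most probably landing near the limit again. For compound 4 the estimate in this assay is 35000 nM, within 7000 nM to 120000 nM.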

Compound 4, half-maximal inhibitory concentration: 8500 nM
Beside the measured number, compound 4's estimate is 4.1-fold (0.61 log units) above it; the range from low to high includes it.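

In this assay, the place on a double-bonded chain carbon bound to a double-bonded ring carbon proves able to hold a group other than thiophen-2-yl without reaching the limit: an at least 5.8-fold lower number from compound 2 to compound 4 (0.76 log units; beyond the scatter) and an at least 5.8-fold lower number from compound 3 to compound 4 (0.76 log units; beyond the scatter). Within the data shown here, compound 2 and compound 3 each stand at a limit and not at a number, so both steps are floors only: the limit of > 50000 nM in this assay, at which 2 of the 4 values shown sit. Against the one earlier read value, a 1.4-fold higher number from compound 1 to compound 4 (0.14 log units; within the scatter), so 6-methylpyridin-2-yl and thiophen-2-yl cannot be told apart in this assay, and the earlier impression that leaving thiophen-2-yl sends the number to the limit no longer holds for compound 4.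

The compounds shown do not separate the contribution of the methyl from that of the ring nitrogen in 6-methylpyridin-2-yl. Open as well is how a plain pyridin-2-yl, or a 6-aminopyridin-2-yl carrying an amine, would read at this place.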